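Swapping a Carboxylated Oxazole for an Isopropyl Pyrazole

A few compounds are considered here, and "the series" means these few. Any claim that something is new, unique, unknown or untested is made for them only; others in the source may bear on it.

Compound 1 `CCCN(CCC)Cc1cc(-c2c(C(=O)NCC)noc2-c2cc(C(C)C)c(O)cc2O)on1` belongs to the same set, but in a functional assay on A2780 cells (Homo sapiens) for inhibition (a higher number here means a weaker inhibitor, a lower number a stronger inhibitor), compound 1 gives "not determined" (no result reported), so no number is reported for it. Among the measured compounds shown here, compound 2 `CCNC(=O)c1noc(-c2cc(C(C)C)c(O)cc2O)c1-c1cc(C(=O)O)no1` is therefore the only compound with a number: in this assay compound 2 gives 20000 nM, and no step between two measured compounds is available to guide the next move. Compound 3 `CCNC(=O)c1noc(-c2cc(C(C)C)c(O)cc2O)c1-c1cnn(C(C)C)c1` differs from compound 2 in one place: 1-isopropyl-1H-pyrazol-4-yl in place of 3-carboxy-1,2-oxazol-5-yl on an aromatic carbon. For the measured compounds named here, with no measured step to rest on, the change is judged on the structures alone, and the step from compound 2 to compound 3 is expected to be large and toward a stronger inhibitor, well beyond the scatter, because compound 2 at 20000 nM leaves ample room for improvement. In this assay compound 3 is estimated at 600 nM, within a range from 60 nM to 6000 nM, which means an expected step of a 33-fold lower number from compound 2 to compound 3 (1.52 log units; beyond the scatter).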

Compound 3, half-maximal inhibitory concentration: 21 nM
Compound 3: the middle estimate sits 29-fold (1.46 log units) above what was measured; measured number below the stated range.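

Replacing 3-carboxy-1,2-oxazol-5-yl with 1-isopropyl-1H-pyrazol-4-yl gives a 950-fold lower number from compound 2 to compound 3 (2.98 log units; beyond the scatter) in this assay and shows that this position, on an aromatic carbon next to the ring atom that bears an ethylcarbamoyl group, strongly affects the read-out. The leaving and entering groups both have 8 heavy atoms and one five-membered aromatic ring with 2 hetero atoms, but the entering group has 0 hydrogen-bond donors and no oxygen, whereas the leaving group has 1 donor and 3 oxygens. No measurement shown accounts for the size of this step.

The ring and its substituent change together, so the compounds shown cannot separate their contributions. They also leave open how a methyl group, a longer chain or a primary amine in place of the isopropyl group would read out.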